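Amino for hydroxy on the 2-hydroxyethoxy chain

The source may report more compounds than this note shows. Statements on the series, on what has been measured and on what is new or still open speak of the compounds shown alone.

Values in a functional assay on MDA-MB-231 cells (Homo sapiens) for cytotoxicity, read by MTT assay, with a stated time of 48 h (on this read-out higher numbers stand for weaker inhibition and lower numbers for stronger inhibition), so far:
- compound 1 (`[N-]=[N+]=NCC/C(=C(\c1ccccc1)c1ccc(OCCO)cc1)c1ccccc1`) gives > 100000 nM (a limit, not a number)
- compound 2 (`NCC/C(=C(\c1ccccc1)c1ccc(OCCO)cc1)c1ccccc1`) gives 25000 nM (a measured number)

Within the data shown here, compound 2 at 25000 nM is the only true number in this assay so far, so it cannot yet be ranked within a range. The next compound, compound 3 (`NCCOc1ccc(/C(=C(/CCN)c2ccccc2)c2ccccc2)cc1`), differs from it by amino in place of hydroxy on a saturated chain carbon, two bonds along the chain from an oxygen on an aromatic ring. Among the measured compounds shown here, one measured step bears on this, an at least 4.0-fold lower number from compound 1 to compound 2 (0.60 log units; beyond the scatter), where amino also entered, though at another place and in place of azido. That step starts from a limit, so it suggests a direction more than a size. A modest further fall in the number is therefore expected, with a 2.5-fold lower number from compound 2 to compound 3 (0.40 log units; beyond the scatter) as the estimated step. For compound 3 the estimated value is 10000 nM, with an expected range of 3000 nM to 30000 nM (both ends estimated).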

Compound 3, half-maximal inhibitory concentration: 17100 nM
Compound 3: middle estimate off by 1.7-fold (0.23 log units), on the low side; the range from low to high includes it.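

In this assay, the change from 2-hydroxyethoxy to 2-aminoethoxy gives a 1.5-fold lower number from compound 2 to compound 3 (0.16 log units; within the scatter), so amino and hydroxy on this saturated chain carbon, two bonds along the chain from an oxygen on an aromatic ring, cannot be told apart here. The earlier step, an at least 4.0-fold lower number from compound 1 to compound 2 (0.60 log units; beyond the scatter), starts from a limit and concerns azido on the other chain, so it showed nothing about this position, and the amino change does not carry over from that chain to this one as a step beyond the scatter. Nothing measured here bears on why the two values lie so close.

Open, from the compounds shown here alone, is whether a dimethylamino group, a carboxylic acid or a longer chain at the end of the 2-aminoethoxy chain would move the number beyond the scatter. Also open, going by these compounds, is the true size of the azido to amino step.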